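This account rests on a few compounds, and the source may have more. Where it says the series, first, only, none or still open, it means among the compounds named here.

Compound 1 (`COc1cc(C(=O)/C=C/c2ccc(OCCCC(=O)NCCCCN(CCCN)CCCCN)cc2)cc(OC)c1OC`) gives 86800 nM
Compound 2 (`COc1ccc(/C=C/C(=O)c2cc(OC)c(OC)c(OC)c2)cc1OCCCC(=O)NCCCCN(CCCN)CCCCN`) gives 82300 nM
Compound 3 (`COc1cc(C(=O)/C=C/c2ccc(OCCCC(=O)NCCCCNCCCN)cc2)cc(OC)c1OC`) gives 54800 nM

All three values come from a functional assay on DU-145 cells (Homo sapiens) for antiproliferative activity, read by MTT assay, with a stated time of 48 h (on this read-out lower numbers stand for stronger inhibition and higher numbers for weaker inhibition), and they do not separate. Compound 2 at 82300 nM sits within the scatter of both other compounds, so no order can be drawn among them. Compound 4 (`COc1ccc(/C=C/C(=O)c2cc(OC)c(OC)c(OC)c2)cc1OCCCC(=O)NCCCCNCCCN`) differs from compound 2 by hydrogen in place of 4-aminobutyl on an amine nitrogen. The same exchange has been measured once, on the other core (a 1.6-fold lower number from compound 1 to compound 3 (0.20 log units; within the scatter)), and that step stays within the scatter. Going by that single step, no change beyond the scatter is expected in this assay and any shift should lean toward a lower number. The expected step (a 1.6-fold lower number from compound 2 to compound 4 (0.20 log units; within the scatter)) is therefore small. Compound 4 is estimated at 52000 nM with 30000 nM to 90000 nM as its expected range.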

Compound 4, half-maximal inhibitory concentration: 99300 nM
Estimate against measurement, compound 4: 1.9-fold (0.28 log units) below; the whole stated range lies below it.
By their numbers in this assay, from the lowest: compounds 3, 2, 1 and 4 (each within the scatter of the next).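

In this assay, the exchange of 4-aminobutyl for hydrogen on the amine nitrogen gives a 1.2-fold higher number from compound 2 to compound 4 (0.08 log units; within the scatter) and stays within the scatter on this second core as well. The lean toward a lower number seen on the core of compound 1 does not recur, and the two steps do not separate: the same change on two cores in this assay, a 1.6-fold lower number (0.20 log units; within the scatter) from compound 1 to compound 3 and a 1.2-fold higher number (0.08 log units; within the scatter) from compound 2 to compound 4, 1.9-fold (0.28 log units) apart, within the scatter of two such steps.

The compounds shown leave open whether another group on this amine nitrogen, such as a longer chain, a methyl group or a carboxylic acid, would move the number beyond the scatter.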